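The source may hold more compounds than are shown below. What is called first, only, known or untested is meant among the compounds shown, and "the series" means these compounds.

Notes on the series in a functional assay on HCT-116 cells (Homo sapiens) for inhibition, read by MTT assay, with a stated time of 48 h (on this read-out lower numbers stand for stronger inhibition and higher numbers for weaker inhibition), follow. Among the measured compounds shown here, compound 3 (`COc1ccc(CNc2cc(OC)c(OC)c(OC)c2)cc1`) gives 18400 nM as the only true number so far. Compound 1 (`COc1cc(NCc2ccccc2)cc(OC)c1OC`) reads > 80000 nM and this is a limit of the assay. Compound 2 (`COc1cc(NCc2ccc(Cl)cc2)cc(OC)c1OC`) reads > 80000 nM and this too is a limit.

Compound 4 (`COc1cc(NCc2ccc(C)cc2)cc(OC)c1OC`) carries methyl in place of methoxy on an aromatic carbon, para to a large group (methyl in place of methoxy on an aromatic carbon).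

For the measured compounds named here, two measured steps bear on this change. With methoxy in place of hydrogen there is an at least 4.3-fold lower number from compound 1 to compound 3 (0.63 log units; beyond the scatter) on record. With methoxy in place of chloro there is an at least 4.3-fold lower number from compound 2 to compound 3 (0.63 log units; beyond the scatter) to set beside it. The remaining pair shows a step that the two limits leave unreadable from compound 1 to compound 2 and adds nothing on size.

Among the three measured compounds, only compound 3 carries this methoxy, and both replacements tested sit on the weaker side of it. With compound 3 at 18400 nM as the starting point, a higher number of modest size is expected for compound 4 in this assay. A result reported only as a limit remains possible for compound 4.

The estimated step is a 2.2-fold higher number from compound 3 to compound 4 (0.34 log units; beyond the scatter) on this reasoning. The estimate for compound 4 is 40000 nM with an expected range from 15000 nM to 80000 nM in this read-out.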

Compound 4, half-maximal inhibitory concentration: > 80000 nM
Compound 4 gave a limit, no number; the forecaster's own chance of this, stated with the estimate: 35%; middle value at least 2.0-fold (0.30 log units) from the limit.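

In this assay, methyl in place of methoxy, para to a large group, gives an at least 4.3-fold higher number from compound 3 to compound 4 (0.63 log units; beyond the scatter), so a carbon substituent at this position does no better than hydrogen or chloro. Methyl keeps the carbon of the methoxy but lacks its oxygen and its one hydrogen-bond acceptor, which shows that this carbon alone does not retain a readable number, and compound 3 remains the only compound of the four with one. The value of compound 4 is a limit of the assay, and the steps among compound 1, compound 2 and compound 4 cannot be read, so hydrogen, chloro and methyl cannot be ordered against one another: the limit of > 80000 nM in this assay, at which 3 of the 4 values shown sit.

Going by these compounds, the true size of the step to compound 4 stays open, since only its lower bound can be read. Also open, on these data alone, is whether a hydroxyl, an ethoxy or an amine at this position would keep a readable number, which would help to separate the part played by the oxygen from that of the rest of the methoxy.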